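The source may hold more compounds than are shown below. What is called first, only, known or untested is meant among the compounds shown, and "the series" means these compounds.

Compound 1 `Clc1cccc(-c2n[nH]cc2N2CCNCC2)c1`: 806 nM.
Compound 2 `Clc1ccc(-c2n[nH]cc2N2CCNCC2)cc1`: 1790 nM.
Compound 3 `Fc1cccc(-c2n[nH]cc2N2CCNCC2)c1`: reported only as a limit, > 10000 nM.

All three were run in an assay on isolated protein for binding affinity to 5-hydroxytryptamine receptor 3A (Homo sapiens); on this read-out higher numbers stand for weaker inhibition and lower numbers for stronger inhibition. Compound 2 gives the higher of the two numbers; the difference between its core and that of compound 1 is not broken down here. Compound 3 carries fluoro in place of chloro on an aromatic carbon relative to compound 1, and the step is an at least 12-fold higher number from compound 1 to compound 3 (1.09 log units; beyond the scatter), open-ended because of the limit of > 10000 nM in this assay, at which 1 of the 3 values shown sits. Compound 4 `Fc1ccc(-c2n[nH]cc2N2CCNCC2)cc1` carries the same kind of change relative to compound 2, (fluoro in place of chloro on an aromatic carbon); here the change sits para to a large group, whereas in compound 3 it sits meta to a large group. Beside an at least 12-fold higher number from compound 1 to compound 3 (1.09 log units; beyond the scatter), a step of about an 8.4-fold higher number from compound 2 to compound 4 (0.92 log units; beyond the scatter) is expected, resting on compound 2 at 1790 nM and on the open-ended step from compound 1 to compound 3. Compound 4 is therefore estimated at 15000 nM, most likely reported only as a limit.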

Compound 4, inhibition constant: > 10000 nM
Compound 4 gave a limit, no number (the forecaster's own chance of this, stated with the estimate: 75%); the middle value does not contradict the limit.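

Fluoro in place of chloro on an aromatic carbon again gives a weaker result in this assay, now para to a large group, with an at least 5.5-fold higher number from compound 2 to compound 4 (0.74 log units; beyond the scatter), so the direction of the change carries from the core of compound 1 to the core of compound 2. Compound 4 is reported only as a limit, so its step has no exact size: the limit of > 10000 nM in this assay, at which 2 of the 4 values shown sit. The direction is shared, but it is not shown that the size of the step carries over: the same change on two cores in this assay, an at least 12-fold higher number (1.09 log units; beyond the scatter) from compound 1 to compound 3 and an at least 5.5-fold higher number (0.74 log units; beyond the scatter) from compound 2 to compound 4; the limit leaves it open whether they differ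

Still open, as far as these compounds go, is how bromo, methyl or trifluoromethyl in place of chloro would read on either core in this assay. Also open, from the compounds shown here alone, is whether an amine or a nitrile on the same aromatic carbon would give a number rather than a limit.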